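A few compounds are considered here, and "the series" means these few. Any claim that something is new, unique, unknown or untested is made for them only; others in the source may bear on it.

Measured so far in an assay on HeLa cells for inhibition of sphingosine-1-phosphate transporter SPNS2 (Mus musculus), read by LC-MS, tested at 2 uM; on this read-out lower numbers stand for less inhibition and higher numbers for more inhibition at the one concentration tested (going by the name of the read-out):

- compound 1, `CCCCCCCCCCc1ccc(-c2noc(CN)n2)cc1`: 62%
- compound 2, `CCCCCCCCCCc1ccc(-c2noc([C@@H]3CCCN3)n2)cc1`: 21%
- compound 3, `CCCCCCCCCCc1ccc(-c2noc([C@@H](N)CCN)n2)cc1`: 14%

Compound 3 gives the lowest of the three numbers in this assay. Its nearest neighbour is compound 2, and the difference a number 7 percentage points lower from compound 2 to compound 3 (within the scatter) lies within the scatter, so the two cannot be ranked against each other. Against compound 1 the gap is clear: a number 48 percentage points lower from compound 1 to compound 3 (beyond the scatter).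

Compound 4, `CCCCCCCCCCc1ccc(-c2noc([C@H](CCCCN)NC(C)=O)n2)cc1`, has not yet been measured. The change from compound 3 is 1-acetamido-5-aminopentyl in place of 1,3-diaminopropyl on an aromatic carbon. Within the data shown here, two measured steps bear on it. Both a number 41 percentage points lower from compound 1 to compound 2 (beyond the scatter) and a number 48 percentage points lower from compound 1 to compound 3 (beyond the scatter) show that enlarging the group on the carbon bearing the amine, relative to aminomethyl, brought large drops in inhibition. The step of a number 7 percentage points lower from compound 2 to compound 3 (within the scatter) between two enlarged variants was within the scatter. Compound 4 carries a still larger group at that carbon, so the expectation for it is a small step, a number 4 percentage points lower from compound 3 to compound 4 (within the scatter), likely within the scatter, in the downward direction if any. The estimate for compound 4 is therefore 10%, with a range from 0% to 28%.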

Compound 4, a percentage reported as inhibition, at one concentration (the size of the read-out at that concentration, not a potency): 40%
The estimate for compound 4 lay 30 percentage points below the measured number; the measured number lies above the stated range.
By their numbers in this assay, from the lowest: compounds 3 and 2 (each within the scatter of the next); then compound 4; then compound 1.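

In this assay, a larger group at this position does not by itself bring a lower number: 1-acetamido-5-aminopentyl in place of 1,3-diaminopropyl gives a number 26 percentage points higher from compound 3 to compound 4 (beyond the scatter), and in place of pyrrolidin-2-yl it gives a number 19 percentage points higher from compound 2 to compound 4 (beyond the scatter), so the drop seen with the earlier replacements of aminomethyl does not simply deepen as the group grows. Aminomethyl still keeps the highest number, with a number 22 percentage points lower from compound 1 to compound 4 (beyond the scatter), so this larger group recovers only part of the ground lost by compound 2 and compound 3. Nothing available explains why the number rises with this group.

The change from compound 3 to compound 4 alters the chain and adds the acetamido group at once, and the compounds shown do not separate the two. On these data alone, whether the chain or the acetamido group carries the rise remains open, and 1,5-diaminopentyl or 1-acetamido-3-aminopropyl at this position would bear on that question.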